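The source may report more compounds than this note shows. Statements on the series, on what has been measured and on what is new or still open speak of the compounds shown alone.

Compound 3 `Cc1cc(/C=C/C#N)cc(C)c1Oc1cc(Nc2ccc(C#N)cc2)c(N)cc1C(=O)N1CC1` gives 12 h in an ADME assay on a cell-free system (plasma, Homo sapiens) for metabolic stability, read by LC-MS, tested at 10 ug/mL (a higher number here means that the compound lasts longer, a lower number that the compound disappears faster), the second highest of the three numbers: compound 1 `Cc1cc(/C=C/C#N)cc(C)c1Oc1cc(Nc2ccc(C#N)cc2)c(N)cc1C(=O)NN` gives 8 h, within the scatter of compound 3, and compound 2 `Cc1cc(/C=C/C#N)cc(C)c1Oc1cc(Nc2ccc(C#N)cc2)c(N)cc1C(=O)NCCC(F)F` gives 57 h. Compound 4 `Cc1cc(/C=C/C#N)cc(C)c1Oc1cc(Nc2ccc(C#N)cc2)c(N)cc1C(=O)OCCC#N` carries 2-cyanoethoxy in place of aziridin-1-yl on a carbonyl carbon. The steps at the same carbonyl carbon bear on this change: a 4.8-fold lower number from compound 2 to compound 3 (0.68 log units; beyond the scatter) and a 1.5-fold higher number from compound 1 to compound 3 (0.18 log units; within the scatter); at the amide-type nitrogen, a 7.1-fold higher number from compound 1 to compound 2 (0.85 log units; beyond the scatter). Replacements at this position have shifted this assay by modest amounts at most, and nothing measured carries a 2-cyanoethoxy group, so the direction is open. For compound 4 the expected step is a 1.2-fold lower number from compound 3 to compound 4 (0.08 log units; within the scatter), not clearly beyond the scatter. The estimate for compound 4 in this assay is 10 h, with a range from 3 h to 35 h.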

Compound 4, half-life: 32 h
Compound 4: middle estimate off by 3.2-fold (0.51 log units), on the low side; measured number inside the range.
By their numbers in this assay, from the lowest: compounds 1 and 3 (each within the scatter of the next); then compounds 4 and 2 (each within the scatter of the next).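

In this assay, 2-cyanoethoxy on the carbonyl carbon separates from aziridin-1-yl, with a 2.7-fold higher number from compound 3 to compound 4 (0.43 log units; beyond the scatter), and from aminoamino, with a 4.0-fold higher number from compound 1 to compound 4 (0.60 log units; beyond the scatter), as a step beyond the scatter. Against (3,3-difluoropropyl)amino it gives a 1.8-fold lower number from compound 2 to compound 4 (0.25 log units; within the scatter), so compounds 2 and 4 now form an upper pair at this position, above compounds 1 and 3. Nothing available accounts for these steps.

Still open, from the compounds shown here alone, is whether a carboxylic acid, a simple methoxy group or a longer chain at this carbonyl carbon would join that upper pair.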